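A Thiophen-2-yl Group Replaces 3-Chlorophenyl on the Chain

This account rests on a few compounds, and the source may have more. Where it says the series, first, only, none or still open, it means among the compounds named here.

Measured compounds:
compound 1, `COc1ccc(C(=O)/C=C/c2ccccn2)c2c1C=CC(C)(C)O2`: 8390 nM
compound 2, `COc1ccc(C(=O)/C=C/c2cccc(Cl)c2)c2c1C=CC(C)(C)O2`: > 10000 nM

Both compounds share one core and differ only in the aryl group at the far end of the double-bonded chain. In a functional assay on SK-OV-3 cells (Homo sapiens) for antiproliferative activity, read by MTT assay, with a stated time of 24 h (a higher number here means a weaker inhibitor, a lower number a stronger inhibitor), compound 1 gives 8390 nM. For compound 2 this assay reports only a limit, > 10000 nM, and no number; compound 2 therefore sits at the limit of > 10000 nM in this assay, at which 1 of the 2 values shown sits, the weaker end of what has been measured here. Among the measured compounds shown here, the one measured step, an at least 1.1-fold higher number from compound 1 to compound 2 (0.07 log units; that floor lies within the scatter), is thus known only as a floor, and that floor lies within the scatter.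

Compound 3, `COc1ccc(C(=O)/C=C/c2cccs2)c2c1C=CC(C)(C)O2`, carries thiophen-2-yl in place of 3-chlorophenyl on a double-bonded chain carbon bound to a double-bonded chain carbon. For the measured compounds named here, the only measured step that touches this position exchanges one aryl group for another, and it gives no firm size, only a floor within the scatter. On that basis compound 3 is expected to stay close to compound 2, with the step that the limit leaves unreadable from compound 2 to compound 3 estimated as small. The estimate for compound 3 in this assay is 11000 nM, with a range from 3500 nM to 35000 nM, and a fair chance that only a limit is again reported.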

Compound 3, half-maximal inhibitory concentration: > 10000 nM
Compound 3: only a limit was reported; the forecaster's own chance of this, stated with the estimate: 50%; the middle value is on the limit's open side.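

With compound 3, a second aryl group reaches the limit of the assay, so a five-membered aromatic ring with 1 hetero atom now stands with the six-membered 3-chlorophenyl ring at the same end of what has been measured: the limit of > 10000 nM in this assay, at which 2 of the 3 values shown sit. Thiophen-2-yl in place of pyridin-2-yl gives an at least 1.1-fold higher number from compound 1 to compound 3 (0.07 log units; that floor lies within the scatter) and so, like the earlier step, is known only as a floor that does not leave the scatter. The step from compound 2 to compound 3 cannot be read, as both values are limits, and thiophen-2-yl and 3-chlorophenyl therefore cannot be ranked against each other in this assay.

The compounds shown leave open whether any group at this place gives a clear step away from pyridin-2-yl. They also leave open how an amine, a carboxylic acid or a longer chain on a double-bonded chain carbon bound to a double-bonded chain carbon would read in this assay.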